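Aryl swap on the shared core: fluorophenyl replacing aminophenyl

The source may report more compounds than this note shows. Statements on the series, on what has been measured and on what is new or still open speak of the compounds shown alone.

Among the measured compounds shown here, compound 1 `COc1cc(-n2cnc3ccc(-c4cccc(N)c4)cc32)cc(OC)c1OC` stands highest of the two numbers measured so far; in a functional assay on MCF7 cells (Homo sapiens) for antiproliferative activity, read by MTT assay, with a stated time of 72 h (a higher number here means a weaker inhibitor, a lower number a stronger inhibitor), compound 1 gives 180 nM. For the measured compounds named here, compound 2 `COc1cc(-n2cnc3ccc(-c4ccc(C)cc4F)cc32)cc(OC)c1OC` gives 56 nM in this assay, and the only measured step, a 3.2-fold lower number from compound 1 to compound 2 (0.51 log units; beyond the scatter), already shows that replacing the 3-aminophenyl can lower the number. Compound 3 `COc1cc(-n2cnc3ccc(-c4ccc(F)cc4)cc32)cc(OC)c1OC` carries a related change, (4-fluorophenyl in place of 3-aminophenyl on an aromatic carbon), which again removes the hydrogen-bond donor and acceptor and again brings in a fluorine on the entering ring. A step of similar direction but smaller size is therefore expected, a 2.0-fold lower number from compound 1 to compound 3 (0.30 log units; within the scatter), with compound 3 estimated at 90 nM in this assay, within 40 nM to 250 nM.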

Compound 3, half-maximal inhibitory concentration: 1770 nM
Compound 3: middle estimate off by 20-fold (1.29 log units), on the low side; measured number outside the range, above it.
By their numbers in this assay, from the lowest: compound 2; then compound 1; then compound 3.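

In this assay, a fluorine on the entering ring does not by itself lower the number at this position: 4-fluorophenyl in place of 3-aminophenyl gives a 9.8-fold higher number from compound 1 to compound 3 (0.99 log units; beyond the scatter). The two fluorinated aryl groups are also far from interchangeable here, with a 32-fold higher number from compound 2 to compound 3 (1.50 log units; beyond the scatter). Nothing measured on these compounds gives a reason for either step.

On these data alone, it remains open whether the methyl group or the fluorine of 2-fluoro-4-methylphenyl, or the two together, carries the lower number of compound 2. A 4-methylphenyl or 2-fluorophenyl group at this place would separate these contributions.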